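The source may report more compounds than this note shows. Statements on the series, on what has been measured and on what is new or still open speak of the compounds shown alone.

Compound 1, with the structure `COC(=O)c1cccc(C2C(C(=O)O)=C(C)N=C(C)/C2=C(/O)OC/C=C/c2ccccc2)c1`, is the starting point here. Among the measured compounds shown here, in a functional assay on thoracic aorta for inhibition of Voltage-gated L-type calcium channel (Rattus norvegicus) (on this read-out lower numbers stand for stronger inhibition and higher numbers for weaker inhibition), compound 1 gives 4400 nM, the highest number among the three compounds measured so far. Two close relatives exist. Compound 2, `CC1=NC(C)=C(C(=O)O)C(c2cccc(F)c2)/C1=C(\O)OC/C=C/c1ccccc1`, carries a fluoro group where compound 1 carries methoxycarbonyl; in this assay compound 2 gives 20 nM. Compound 3, `CC1=NC(C)=C(C(=O)O)C(c2cccc(Br)c2)/C1=C(\O)OC/C=C/c1ccccc1`, carries bromo at that same place; in this assay compound 3 gives 10 nM. Exchanging the methoxycarbonyl group for fluoro brought a 220-fold lower number from compound 1 to compound 2 (2.34 log units; beyond the scatter), and exchanging it for bromo brought a 440-fold lower number from compound 1 to compound 3 (2.64 log units; beyond the scatter). Between the two halogen compounds the step was a 2.0-fold lower number from compound 2 to compound 3 (0.30 log units; within the scatter).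

Compound 4, `CC1=NC(C)=C(C(=O)O)C(c2cccc(I)c2)/C1=C(\O)OC/C=C/c1ccccc1`, has not yet been measured. It differs from compound 1 in a single place: iodo in place of methoxycarbonyl on an aromatic carbon. Both measured replacements of the methoxycarbonyl group by a halogen gave a large drop in the number, and the two halogens gave numbers within the usual scatter of each other, so a change of the same kind is expected for iodo. Compound 4 is therefore expected to give 8 nM, within a range from 3 nM to 30 nM. That expectation means a step of a 550-fold lower number from compound 1 to compound 4 (2.74 log units; beyond the scatter), resting on a 220-fold lower number from compound 1 to compound 2 (2.34 log units; beyond the scatter) and a 440-fold lower number from compound 1 to compound 3 (2.64 log units; beyond the scatter).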

Compound 4, half-maximal inhibitory concentration: 13 nM
For compound 4 the middle estimate is 1.6-fold (0.21 log units) below the measured one; the measured number falls inside the stated range.
By their numbers in this assay, from the lowest: compounds 3, 4 and 2 (each within the scatter of the next); then compound 1.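

In this assay, a third halogen repeats the large effect seen with fluoro and bromo: iodo in place of methoxycarbonyl on the aromatic ring brings a 340-fold lower number from compound 1 to compound 4 (2.53 log units; beyond the scatter). The three halogen compounds cannot be told apart, since iodo in place of bromo gives a 1.3-fold higher number from compound 3 to compound 4 (0.11 log units; within the scatter) and iodo in place of fluoro gives a 1.5-fold lower number from compound 2 to compound 4 (0.19 log units; within the scatter), so across fluoro, bromo and iodo the choice of halogen makes no measurable difference at this position, and the one clear divide lies between the halogens and methoxycarbonyl. Nothing shown here accounts for that divide or for the sameness of the halogens.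

The compounds shown hold only methoxycarbonyl and halogens at this place, so it remains open where groups such as methyl, methoxy, nitrile or a carboxylic acid would fall, and whether a plain hydrogen would read like the halogen compounds or like compound 1. As far as these compounds go, it is also open whether the halogen result carries over to other places on the same ring, since every comparison here concerns this single position.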